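The source may report more compounds than this note shows. Statements on the series, on what has been measured and on what is new or still open speak of the compounds shown alone.

Measured so far, in an assay on isolated protein for inhibition of acyl-CoA desaturase 1 (Rattus norvegicus); a higher number here means a weaker inhibitor, a lower number a stronger inhibitor:
- compound 1 `CS(=O)(=O)c1ccc2nc(-c3ccc(-c4ccc(F)cc4)cc3)[nH]c2c1`, giving 25 nM
- compound 2 `CS(=O)(=O)c1ccc2nc(-c3ccc(-c4ccsc4)cc3)[nH]c2c1`, giving 104 nM

Going by the values given here, of these two, compound 2 gives the higher number, and the single measured step, a 4.2-fold higher number from compound 1 to compound 2 (0.62 log units; beyond the scatter), lies beyond the scatter. Compound 3 `Cc1ccsc1-c1ccc(-c2nc3ccc(S(C)(=O)=O)cc3[nH]2)cc1` is not yet measured; it differs from compound 2 in one place: 3-methylthiophen-2-yl in place of thiophen-3-yl on an aromatic carbon. Among the compounds with values here, no measured step exchanges one thiophene for another, so the only guide is a 4.2-fold higher number from compound 1 to compound 2 (0.62 log units; beyond the scatter), which shows that a change at this position can shift this assay by a modest amount. Exchanging thiophen-3-yl for 3-methylthiophen-2-yl is a smaller change than replacing 4-fluorophenyl with a thiophene ring, so the expected step of a 1.0-fold lower number from compound 2 to compound 3 (0.02 log units; within the scatter) is small, with no clear direction. Compound 3 is therefore expected to give about 100 nM, within a range from 30 nM to 350 nM.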

Compound 3, half-maximal inhibitory concentration: 472 nM
The estimate for compound 3 lay 4.7-fold (0.67 log units) below the measured number; the measured number lies above the stated range.
By their numbers in this assay, from the lowest: compound 1; then compound 2; then compound 3.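

Exchanging one thiophene for another is not a minor edit at this position: in this assay it gives a 4.5-fold higher number from compound 2 to compound 3 (0.66 log units; beyond the scatter), a modest step, as was a 4.2-fold higher number from compound 1 to compound 2 (0.62 log units; beyond the scatter), even though both compounds carry a five-membered aromatic ring with one hetero atom. Set against the 4-fluorophenyl group, 3-methylthiophen-2-yl gives a 19-fold higher number from compound 1 to compound 3 (1.28 log units; beyond the scatter), a large step, so this position is sensitive to the exact ring placed on it and not merely to the ring's general type. No other measurement is available to explain this sensitivity.

Going by these compounds, the step from compound 2 to compound 3 alters the ring's point of attachment and adds a methyl group together, so the share of each remains unknown; plain thiophen-2-yl would separate them. On these data alone, how a ring bearing an amine or a carboxylic acid would behave here also stays open.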